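This account rests on a few compounds, and the source may have more. Where it says the series, first, only, none or still open, it means among the compounds named here.

Measured compounds in a functional assay on PC-3 cells (Homo sapiens) for inhibition; on this read-out lower numbers stand for stronger inhibition and higher numbers for weaker inhibition:

- Compound 1 `Cc1c(C(=O)N/N=C\c2ccccc2O)oc2cccc(O)c12` gives 8350 nM
- Compound 2 `Cc1c(C(=O)N/N=C\c2cc(O)ccc2O)oc2cccc(O)c12` gives 95500 nM
- Compound 3 `Cc1ccc(O)c(/C=N\NC(=O)c2oc3cccc(O)c3c2C)c1` gives 7350 nM

Compound 3 has the lowest number of the three, but its gap to compound 1 is within the scatter, as a 1.1-fold lower number from compound 1 to compound 3 (0.06 log units; within the scatter) shows, so the two cannot be ranked; only compound 2 stands clearly apart, with a 13-fold lower number from compound 2 to compound 3 (1.11 log units; beyond the scatter).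

Compound 4 `Cc1c(C(=O)N/N=C\c2cc([N+](=O)[O-])ccc2O)oc2cccc(O)c12` differs from compound 3 by nitro in place of methyl on an aromatic carbon, that is, on an aromatic carbon of a six-membered aromatic ring of carbon only, meta to a large group and para to a hydroxy group.

Among the measured compounds shown here, two measured steps touch the same position. Placing hydroxy there gave an 11-fold higher number from compound 1 to compound 2 (1.06 log units; beyond the scatter), a large rise, while placing methyl there gave a 1.1-fold lower number from compound 1 to compound 3 (0.06 log units; within the scatter), no change beyond the scatter. Nitro, like hydroxy, brings hydrogen-bond acceptors to that carbon, and so a rise in this assay is expected for compound 4, though the data cannot fix its size: the expected step is a 4.1-fold higher number from compound 3 to compound 4 (0.61 log units; beyond the scatter), giving an estimate of 30000 nM, with a range from 8000 nM to 120000 nM.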

Compound 4, half-maximal inhibitory concentration: 17100 nM
Beside the measured number, compound 4's estimate is 1.8-fold (0.24 log units) above it; low and high end bracket the measured number.
By their numbers in this assay, from the lowest: compounds 3 and 1 (each within the scatter of the next); then compound 4; then compound 2.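

In this assay, nitro at this carbon gives a modest rise, both against methyl, a 2.3-fold higher number from compound 3 to compound 4 (0.37 log units; beyond the scatter), and against plain hydrogen, a 2.0-fold higher number from compound 1 to compound 4 (0.31 log units; beyond the scatter), so this carbon does not accept every group as freely as the methyl result alone suggested. Yet nitro stays well short of the penalty seen with hydroxy, a 5.6-fold lower number from compound 2 to compound 4 (0.75 log units; beyond the scatter), which shows that the two groups do not act alike here and that the position separates at least three levels: hydrogen and methyl, then nitro, then hydroxy. Nothing shown gives a reason for this order.

Going by these compounds, whether an amine or a carboxylic acid at this carbon would land nearer nitro or hydroxy remains open. So does whether the same order would hold at another carbon of this ring.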